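This account rests on a few compounds, and the source may have more. Where it says the series, first, only, none or still open, it means among the compounds named here.

In a functional assay on the whole organism for inhibition, with Rattus norvegicus as the target (on this read-out higher numbers stand for an effect only at larger amounts of compound and lower numbers for an effect already at smaller amounts), compound 1 `Oc1nnc(-c2nc3ccccc3o2)o1` gives 3 mg/kg. Compound 3 `Cc1ccc2nc(-c3nnc(O)o3)oc2c1` gives 2 mg/kg, within the scatter of compound 1, while compound 2 `COC(=O)c1cc(OC)c2oc(-c3nnc(O)o3)nc2c1` gives 9 mg/kg, a number clearly higher than that of compound 1. Compound 4 `Cc1ccc2oc(-c3nnc(O)o3)nc2c1` differs from compound 1 by methyl in place of hydrogen on an aromatic carbon, with methyl in place of hydrogen on an aromatic carbon. For the measured compounds named here, one measured step bears on this change: a 1.5-fold lower number from compound 1 to compound 3 (0.18 log units; within the scatter), the same kind of replacement, and it stays within the scatter. Going by the values given here, compound 2 differs from compound 1 in more than one place and offers no such step. The expected step is small, a 1.2-fold lower number from compound 1 to compound 4 (0.08 log units; within the scatter), with no shift beyond the scatter anticipated. For compound 4 the estimated value is 2.5 mg/kg, with an expected range from 1 mg/kg to 6 mg/kg.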

Compound 4, dose for half-maximal effect: 2 mg/kg
Compound 4: the middle estimate sits 1.3-fold (0.10 log units) above what was measured, and the stated range covers the measured number.
By their numbers in this assay, from the lowest: compounds 3, 4 and 1 (each within the scatter of the next); then compound 2.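

In this assay, placing methyl on this aromatic carbon, meta to a fused ring and para to a fused ring, gives a 1.5-fold lower number from compound 1 to compound 4 (0.18 log units; within the scatter), so the change stays within the scatter here too. Compound 3 carries its methyl on another aromatic carbon, and compound 3 at 2 mg/kg and compound 4 at 2 mg/kg print the same number, so the two placements show no separation. Nothing available explains this result. Methyl is the only group shown at this carbon, so it stays open whether a longer chain, an amine or a carboxylic acid there would also stay within the scatter of compound 1.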